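Triazole thioether series: cytotoxicity notes toward compound 4

This account rests on a few compounds, and the source may have more. Where it says the series, first, only, none or still open, it means among the compounds named here.

compound 1 `CCOC(=O)CSc1nnc(C)n1N1C(=O)c2ccccc2C1=O`: > 200000 nM
compound 2 `C#CCSc1nnc(C)n1N1C(=O)c2ccccc2C1=O`: > 200000 nM
compound 3 `C=CCSc1nnc(CC)n1N1C(=O)c2ccccc2C1=O`: > 200000 nM

In a functional assay on A549 cells (Homo sapiens) for cytotoxicity, read by MTT assay, with a stated time of 48 h (on this read-out higher numbers stand for weaker inhibition and lower numbers for stronger inhibition), compound 1 gives > 200000 nM, which is a limit of the assay and not a number. Compound 2 gives > 200000 nM in this assay, again a limit. Compound 3 gives > 200000 nM in this assay, also a limit. Within the data shown here, compound 3 thus stands at the limit where every value so far sits, (the limit of > 200000 nM in this assay, at which 3 of the 3 values shown sit). Among the measured compounds shown here, the single step between measured compounds that differ in one place, a step that the two limits leave unreadable from compound 1 to compound 2, cannot be read, since both of its ends are limits.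

Compound 4 `CCc1nnc(SCC(=O)c2ccc(Cl)cc2)n1N1C(=O)c2ccccc2C1=O` differs from compound 3 by (4-chlorophenyl)carbonyl in place of vinyl on a saturated chain carbon bound to a sulfur. For the measured compounds named here, no measured step bears on this change; the only comparable step stays unreadable, so no direction can be taken from it. Compound 4 is expected to sit near 150000 nM, within a range of 40000 nM to 300000 nM, and most likely to return a limit again. The step of an at least 1.3-fold lower number from compound 3 to compound 4 (0.12 log units; that floor lies within the scatter) is therefore expected to stay within the scatter.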

Compound 4, half-maximal inhibitory concentration: > 200000 nM
Compound 4: no number, only a limit (the forecaster's own chance of this, stated with the estimate: 60%); middle value at least 1.3-fold (0.12 log units) from the limit.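

Compound 4 gives > 200000 nM in this assay, a limit of the assay and not a number; with compound 3 also at a limit, the step between the two cannot be read. The compounds shown leave open whether any change on the saturated chain carbon bound to a sulfur gives a readable number, since every value shown remains a limit: the limit of > 200000 nM in this assay, at which 4 of the 4 values shown sit.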